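Working notes toward compound 4 in the efficacy read-out

The source may hold more compounds than are shown below. What is called first, only, known or untested is meant among the compounds shown, and "the series" means these compounds.

Three compounds of this set carry numbers in an in vitro functional assay on HEK285-7 cells for antagonist activity at prostaglandin D2 receptor 2 (Homo sapiens), read by BRET and beta-arrestin recruitment; on this read-out lower numbers stand for smaller maximal responses and higher numbers for larger maximal responses. Compound 1 `O=C(O)Cc1sc(C(c2ccc(F)cc2)c2ccc(F)cc2)nc1-c1ccccc1` gives 80% in this assay. Compound 2 `O=C(O)Cc1sc(C(c2ccc(F)cc2)c2ccc(F)cc2)nc1-c1ccoc1` gives 80%, and the step of no change at the digits printed from compound 1 to compound 2 (within the scatter). Compound 3 `NS(=O)(=O)c1cccc(-c2nc(C(c3ccc(F)cc3)c3ccc(F)cc3)sc2CC(=O)O)c1` gives 55%, which is the lowest of the three numbers: the step of a number 25 percentage points lower from compound 1 to compound 3 (beyond the scatter), and the step of a number 25 percentage points lower from compound 2 to compound 3 (beyond the scatter).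

Compound 4 `O=C(O)Cc1sc(C(c2ccc(F)cc2)c2ccc(F)cc2)nc1-c1cc(F)nc(F)c1` has no number yet. It differs from compound 3 as follows: 2,6-difluoropyridin-4-yl in place of 3-sulfamoylphenyl on an aromatic carbon. Both measured steps that end at compound 3 bear on this change, since each introduced the sulfamoyl-bearing ring that now leaves; both were modest and both pointed downward. The entering group counts no hydrogen-bond donor, like the phenyl of compound 1 and the furan-3-yl of compound 2, and those two compounds sit within the scatter of each other. For the measured compounds named here, no measured step covers a six-membered ring with a hetero atom or a fluorine on that ring, so that part of the change is uncharted. On balance a modest upward step is expected, a number 20 percentage points higher from compound 3 to compound 4 (beyond the scatter), returning toward the numbers of compounds 1 and 2. For compound 4 the expected value in this assay is 75%, with an estimated range from 60% to 90%.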

Compound 4, largest response reached (reported as efficacy), in percent of the reference or control that the assay uses: 80%
Beside the measured number, compound 4's estimate is 5 percentage points below it; low and high end bracket the measured number.
By their numbers in this assay, from the lowest: compound 3; then compounds 1, 2 and 4 (each within the scatter of the next).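

In this assay, the step of a number 25 percentage points higher from compound 3 to compound 4 (beyond the scatter) shows that the lower number of compound 3 does not carry over to every replacement of its ring at this aromatic carbon, next to the ring nitrogen. For the compounds shown here, the steps of no change at the digits printed from compound 2 to compound 4 (within the scatter) and no change at the digits printed from compound 1 to compound 4 (within the scatter) extend the earlier match between phenyl and furan-3-yl to 2,6-difluoropyridin-4-yl, a six-membered aromatic ring with a hetero atom and fluorine substituents, leaving 3-sulfamoylphenyl in compound 3 as the only one of the four groups set apart at this position. No supporting data bear on why these groups separate in this way.

The compounds shown leave open whether the lower number belongs to the sulfamoyl group specifically or would also appear with an amine or a carboxylic acid in its place on the phenyl ring. They also leave open whether the ring nitrogen and the two fluorines each matter in this read-out, a question that unsubstituted pyridin-4-yl or a 3,5-difluorophenyl group at the same carbon would address.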